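From chloro to trifluoromethyl on an aromatic carbon

The compounds below may be only part of what the source reports. "The series", "measured", "known", "first", "only" and "open" are said of these compounds alone.

Three related compounds have been tested in an ADME assay on Vero 76 cells (Chlorocebus sabaeus) for cytotoxicity, read by MTT assay, with a stated time of 96 h; a lower number here means that less compound is tolerated, a higher number that more compound is tolerated. Compound 3 `Cc1ccc(NCc2cn(-c3ccccc3)nc2-c2ccc(Cl)cc2)cc1` reads > 100000 nM, and this is a limit of the assay, not a number. Compound 1 `FC(F)(F)c1ccc(-c2nn(-c3ccccc3)cc2CNc2ccc(Cl)cc2)cc1` gives 10000 nM. Compound 2 `Brc1ccc(NCc2cn(-c3ccccc3)nc2-c2ccccc2)cc1` gives 52000 nM. Compound 3 therefore has no exact position, only a place at the tolerated end of the scale, and the numbers of the other two both fall short of its limit.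

Compound 4 `Cc1ccc(NCc2cn(-c3ccccc3)nc2-c2ccc(C(F)(F)F)cc2)cc1` has not yet been measured. It differs from compound 3 in one place: trifluoromethyl in place of chloro on an aromatic carbon. Trifluoromethyl stands in place of chloro on an aromatic carbon, para to a large group. Going by the values given here, no measured pair of compounds isolates this change, so its size can only be judged indirectly. Among the compounds with values here, the one tested compound carrying trifluoromethyl, compound 1, gives 10000 nM, although it also differs from compound 4 elsewhere. On that basis, a move toward less compound being tolerated is expected, beyond the usual scatter but uncertain in size. The expected step is an at least 2.5-fold lower number from compound 3 to compound 4 (0.39 log units; beyond the scatter). Compound 4 is estimated at 40000 nM, with an expected range from 12000 nM to 100000 nM.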

Compound 4, half-maximal cytotoxic concentration: 82000 nM
Beside the measured number, compound 4's estimate is 2.1-fold (0.31 log units) below it; the range from low to high includes it.
By their numbers in this assay, from the lowest: compound 1; then compounds 2 and 4 (each within the scatter of the next). At a limit, above all of these: compound 3.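

Compound 3 is known only as a limit of the assay, not as a number, and the change to trifluoromethyl can be sized from one side only because of that limit: the limit of > 100000 nM in this assay, at which 1 of the 4 values shown sits.

Read from that side, the change from 4-chlorophenyl to 4-(trifluoromethyl)phenyl in this assay gives an at least 1.2-fold lower number from compound 3 to compound 4 (0.08 log units; that floor lies within the scatter), so this swap need not lower the number at all, although a larger drop remains possible. Going by these compounds alone, the new value also creates a second comparison, with methyl in place of chloro on an aromatic carbon, which gives an 8.2-fold higher number from compound 1 to compound 4 (0.91 log units; beyond the scatter), the first single change in this set that can be read as beyond the scatter.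

From the compounds shown here alone, the true size of the step from chloro to trifluoromethyl stays open for as long as compound 3 has only a limit and no exact value. Also open is how an amine or a carboxylic acid on that same aromatic carbon would read in this assay, since the compounds shown carry only chloro and trifluoromethyl there.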